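The compounds below may be only part of what the source reports. "The series", "measured", "known", "first", "only" and "open" are said of these compounds alone.

Three compounds were measured in a functional assay on HL-60 cells (Homo sapiens) for antiproliferative activity, with a stated time of 24 h; on this read-out lower numbers stand for stronger inhibition and higher numbers for weaker inhibition:

Compound 1 `NC(=O)c1c(NC(=O)c2ccccc2Cl)sc2c1CCN(Cc1c(Cl)cccc1Cl)C2`: 4850 nM
Compound 2 `NC(=O)c1c(NC(=O)c2ccccc2Cl)sc2c1CCN(Cc1ccc(Cl)cc1Cl)C2`: 8010 nM
Compound 3 `NC(=O)c1c(NC(=O)c2ccc(C(F)(F)F)cc2)sc2c1CCN(Cc1c(Cl)cccc1Cl)C2`: 10600 nM

Compound 2 differs from compound 1 by 2,4-dichlorophenyl in place of 2,6-dichlorophenyl on a saturated chain carbon bound to an amine nitrogen in a ring, and this gave a 1.7-fold higher number from compound 1 to compound 2 (0.22 log units; within the scatter). Compound 3 differs from compound 1 by 4-(trifluoromethyl)phenyl in place of 2-chlorophenyl on a carbonyl carbon, which gave a 2.2-fold higher number from compound 1 to compound 3 (0.34 log units; beyond the scatter). The values of compound 2 and compound 3 in this assay lie within the scatter of each other.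

Compound 4 `NC(=O)c1c(NC(=O)c2ccc(C(F)(F)F)cc2)sc2c1CCN(Cc1ccc(Cl)cc1Cl)C2` has not yet been measured. For the measured compounds named here, it differs from compound 3 by 2,4-dichlorophenyl in place of 2,6-dichlorophenyl on a saturated chain carbon bound to an amine nitrogen in a ring, the same change as the one from compound 1 to compound 2, made on the core of compound 3 instead of the core of compound 1. Going by the values given here, only one example of this change is known here, so the expectation rests on a single step. Compound 4 is expected to show a 1.4-fold higher number from compound 3 to compound 4 (0.15 log units; within the scatter), a step of about the same size as the one seen in a 1.7-fold higher number from compound 1 to compound 2 (0.22 log units; within the scatter), which stayed within the scatter. On that basis compound 4 is estimated at 15000 nM, expected to fall between 7000 nM and 32000 nM.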

Compound 4, half-maximal inhibitory concentration: 14900 nM
Compound 4: middle estimate off by 1.0-fold (0.00 log units), on the high side; the range from low to high includes it.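

In this assay, for the compounds shown here, 2,4-dichlorophenyl in place of 2,6-dichlorophenyl gave a 1.4-fold higher number from compound 3 to compound 4 (0.15 log units; within the scatter), and the step carried over from one core to the other with no difference beyond the scatter: the same change on two cores in this assay, a 1.7-fold higher number (0.22 log units; within the scatter) from compound 1 to compound 2 and a 1.4-fold higher number (0.15 log units; within the scatter) from compound 3 to compound 4, 1.2-fold (0.07 log units) apart, within the scatter of two such steps The second change, 4-(trifluoromethyl)phenyl in place of 2-chlorophenyl on a carbonyl carbon, gave a 1.9-fold higher number from compound 2 to compound 4 (0.27 log units; within the scatter), and it also carried over: the same change on two cores in this assay, a 2.2-fold higher number (0.34 log units; beyond the scatter) from compound 1 to compound 3 and a 1.9-fold higher number (0.27 log units; within the scatter) from compound 2 to compound 4, 1.2-fold (0.07 log units) apart, within the scatter of two such steps Across these compounds the two changes therefore behave as if independent of each other, but each rests on only two closely related cores, and three of the four steps lie within the scatter, so this neither establishes a real effect of the dichlorophenyl change nor shows that either change would carry over to other cores.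

The compounds shown leave open whether a longer chain in place of the single saturated carbon on the ring amine would shift the number beyond the scatter. They also leave open what a nitrile in place of the primary amide, or an amine on the aromatic ring of the acyl group, would do.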